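The source may hold more compounds than are shown below. What is called first, only, known or untested is meant among the compounds shown, and "the series" means these compounds.

Measured compounds in a functional assay on A549 cells (Homo sapiens) for antiproliferative activity, read by XTT assay, with a stated time of 72 h; a higher number here means a weaker inhibitor, a lower number a stronger inhibitor:
- compound 1, `COc1ccc(-c2cc3ccccc3nc2/C=C/C(=O)c2ccc(N)cc2)cc1`: 7530 nM
- compound 2, `COc1ccc(-c2cc3ccccc3nc2/C=C/C(=O)c2ccco2)cc1`: 6130 nM

Compound 2 and compound 1 share the core and differ only in the aryl group on the carbonyl carbon. Within the data shown here, the single measured step, a 1.2-fold lower number from compound 1 to compound 2 (0.09 log units; within the scatter), lies within the scatter, so the two numbers are not separated from each other and compound 2 cannot be set apart from compound 1 on this evidence.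

Compound 3, `COc1ccc(-c2cc3ccccc3nc2/C=C/C(=O)c2ccc[nH]2)cc1`, is the next member. The change from compound 2 reads (1H-pyrrol-2-yl in place of furan-2-yl on a carbonyl carbon). It keeps the same five-membered ring size and the same point of attachment and exchanges only the ring hetero atom.

Among the measured compounds shown here, no measured step exchanges the furan-2-yl for another five-membered ring, so nothing bears on it directly. For the measured compounds named here, the only step at this position, a 1.2-fold lower number from compound 1 to compound 2 (0.09 log units; within the scatter), replaced one aryl group by another and stayed within the scatter. On that basis the step to compound 3 is expected to be a 1.1-fold lower number from compound 2 to compound 3 (0.05 log units; within the scatter), that is, none beyond the scatter. Compound 3 is therefore estimated at 5500 nM in this assay, within a range of 2500 nM to 12000 nM.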

Compound 3, half-maximal inhibitory concentration: > 10000 nM
Compound 3: a limit, no number (the forecaster's own chance of this, stated with the estimate: 5%); middle value at least 1.8-fold (0.25 log units) away from the limit.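

Compound 3 gives > 10000 nM in this assay, which is a limit of the assay and not a number, and it is the only value of this kind at this position: the limit of > 10000 nM in this assay, at which 1 of the 3 values shown sits.

The earlier pair showed only a step within the scatter between two measured numbers, whereas the exchange of furan-2-yl for 1H-pyrrol-2-yl on a carbonyl carbon, which keeps the ring size and replaces a hydrogen-bond acceptor with a hydrogen-bond donor, gives a step with a floor and no upper bound: an at least 1.6-fold higher number from compound 2 to compound 3 (0.21 log units; that floor lies within the scatter). The comparison with the 4-aminophenyl group has the same form, an at least 1.3-fold higher number from compound 1 to compound 3 (0.12 log units; that floor lies within the scatter), so both steps may be small or large, and neither can be placed beyond the scatter on the present values.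

From the compounds shown here alone, the true size of either step remains open, as does whether the outcome follows the hydrogen on the ring nitrogen or the ring hetero atom itself. A 1-methyl-1H-pyrrol-2-yl or a thiophen-2-yl group at the same place would bear on that question, but neither is among the compounds shown.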